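The source may report more compounds than this note shows. Statements on the series, on what has been measured and on what is new or still open speak of the compounds shown alone.

Compound 3, `COc1cc2nc(N3CCN(C(=O)OCc4ccccc4)[C@@H]4CCCC[C@@H]43)nc(N)c2cc1OC`, gives the lowest number of the three measured in an assay on CHO cells for displacement of a labelled ligand from Alpha-1B adrenergic receptor (Homo sapiens), with a stated time of 30 min; on this read-out higher numbers stand for weaker inhibition and lower numbers for stronger inhibition; compound 2, `COc1cc2nc(N3CCN(C(=O)C(C)(C)C)[C@H]4CCCC[C@H]43)nc(N)c2cc1OC`, gives 0.776 nM, and compound 1, `CCCCCC(=O)N1CCN(c2nc(N)c3cc(OC)c(OC)cc3n2)[C@@H]2CCCC[C@@H]21`, gives 0.912 nM, while compound 3 itself gives 0.191 nM. Compound 4, `COc1cc2nc(N3CCN(C(=O)OCc4ccccc4)[C@H]4CCCC[C@H]43)nc(N)c2cc1OC`, is its mirror image: the two compounds have the same atoms and bonds and differ only in configuration as drawn: 2 of 2 stereo elements differ (all stereocentres are inverted: mirror images); a stereocentre at a saturated ring carbon is drawn R in compound 3 and S in compound 4; a stereocentre at a saturated ring carbon is drawn S in compound 3 and R in compound 4. For the measured compounds named here, the only measured step, a 1.2-fold lower number from compound 1 to compound 2 (0.07 log units; within the scatter), exchanges one acyl group for another and says nothing about inversion of both ring stereocentres; no pair shows that change. The expectation is therefore wide, leaning toward a somewhat weaker number, with the step from compound 3 expected as a 7.9-fold higher number from compound 3 to compound 4 (0.90 log units; beyond the scatter). Compound 4 is estimated at 1.5 nM, within a range from 0.15 nM to 15 nM.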

Compound 4, inhibition constant: 0.38 nM
Beside the measured number, compound 4's estimate is 3.9-fold (0.60 log units) above it, within the range that was stated.
By their numbers in this assay, from the lowest: compounds 3 and 4 (each within the scatter of the next); then compounds 2 and 1 (each within the scatter of the next).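

In this assay, for the compounds shown here, inversion of both ring stereocentres, a change no earlier pair covered, gives a 2.0-fold higher number from compound 3 to compound 4 (0.30 log units; within the scatter), so with benzyloxy on the carbonyl carbon this mirror pair is not told apart, and only configuration varies within it: the fact that compounds 3 and 4 differ only in the configuration as drawn. Going by these compounds alone, the acyl exchanges also read for the first time beyond the scatter, though modestly, with a 2.0-fold lower number from compound 2 to compound 4 (0.31 log units; beyond the scatter) and a 2.4-fold lower number from compound 1 to compound 4 (0.38 log units; beyond the scatter).

On these data alone, whether inversion reads the same with tert-butyl or pentyl on the carbonyl carbon stays open. So does how a longer chain or an amine in place of benzyloxy would read.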